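Fluorophenyl Amide Replaces Nitrophenyl on the Triazole Ring

The compounds below may be only part of what the source reports. "The series", "measured", "known", "first", "only" and "open" are said of these compounds alone.

Compound 3 `CCOC(=O)C1=Cc2ccccc2OC1(OCc1cn(-c2ccc(F)c([N+](=O)[O-])c2)nn1)C(F)(F)F` gives 15600 nM in a functional assay on HeLa cells (Homo sapiens) for inhibition, read by MTT assay, with a stated time of 24 h; a lower number here means a stronger inhibitor, a higher number a weaker inhibitor. Compound 1 `CCOC(=O)C1=Cc2ccccc2OC1(OCc1cn(CC(=O)Nc2cccc(Cl)c2)nn1)C(F)(F)F` gives 12300 nM in this assay. Compound 2 `CCOC(=O)C1=Cc2ccccc2OC1(OCc1cn(CC(=O)Nc2ccccc2Br)nn1)C(F)(F)F` reaches only the limit of this assay, > 150000 nM, so no number is known for it. Among the two numbers, compound 3 stands highest, with compound 1 nearest, and the step of a 1.3-fold higher number from compound 1 to compound 3 (0.10 log units; within the scatter) is within the scatter, so the two cannot be ranked.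

Compound 4 `CCOC(=O)C1=Cc2ccccc2OC1(OCc1cn(CC(=O)Nc2ccccc2F)nn1)C(F)(F)F` has not been measured. The change is ((2-fluorophenyl)carbamoyl)methyl in place of 4-fluoro-3-nitrophenyl on an aromatic nitrogen. For the measured compounds named here, two measured steps bear on it. The step of an at least 12-fold higher number from compound 1 to compound 2 (1.08 log units; beyond the scatter) shows that a 2-bromophenyl amide weakens inhibition strongly, to the limit (the limit of > 150000 nM in this assay, at which 1 of the 3 values shown sits). The step of an at least 9.6-fold lower number from compound 2 to compound 3 (0.98 log units; beyond the scatter) shows the reverse move. Compound 4 shares with compound 2 the 2-halophenyl amide arrangement, with fluorine in place of bromine, so a step toward a higher number is expected, estimated as a 3.2-fold higher number from compound 3 to compound 4 (0.51 log units; beyond the scatter). Compound 4 is therefore expected to give about 50000 nM in this assay, estimated between 12000 nM and 200000 nM.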

Compound 4, half-maximal inhibitory concentration: 49900 nM
Compound 4: the middle estimate sits 1.0-fold (0.00 log units) above what was measured; the range from low to high includes it.
By their numbers in this assay, from the lowest: compounds 1 and 3 (each within the scatter of the next); then compound 4. At a limit, above all of these: compound 2.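

With all else unchanged, fluoro in place of bromo on an aromatic carbon gives an at least 3.0-fold lower number from compound 2 to compound 4 (0.47 log units; beyond the scatter), so in this assay a halogen change alone brings a phenyl amide of this kind back to a measurable value. Compound 2 itself gives a limit and not a number: the limit of > 150000 nM in this assay, at which 1 of the 4 values shown sits. Even so, the 2-fluorophenyl amide remains a weaker inhibitor than the other two compounds, with a 3.2-fold higher number from compound 3 to compound 4 (0.50 log units; beyond the scatter) and a 4.1-fold higher number from compound 1 to compound 4 (0.61 log units; beyond the scatter), so an amide-linked arm on the aromatic nitrogen does not by itself match them.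

Compound 1 and compound 4 differ in both the halogen and its ring position, and the compounds shown cannot separate these two changes, which a 2-chlorophenyl or 3-fluorophenyl amide could do. Also open, going by these compounds, is how an unsubstituted phenyl amide, or an amine on that phenyl ring, would read.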